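This account rests on a few compounds, and the source may have more. Where it says the series, first, only, none or still open, it means among the compounds named here.

Compound 1, `O=C(/C=C\c1ccccc1O)N1N=C(c2ccncc2)OC1c1c[nH]c2ccccc12`, was examined in an ADME assay on A549 cells (Homo sapiens) for cytotoxicity, read by MTT assay, with a stated time of 48 h; on this read-out lower numbers stand for stronger inhibition of growth and higher numbers for weaker inhibition of growth. In this assay compound 1 gives > 30 ug/mL, which is a limit of the assay and not a number. Two close relatives show the same picture. Compound 2, `O=C(/C=C\c1ccc([N+](=O)[O-])cc1)N1N=C(c2ccncc2)OC1c1c[nH]c2ccccc12`, gives > 30 ug/mL in this assay, again only a limit. Compound 3, `O=C(/C=C\c1ccc(F)cc1)N1N=C(c2ccncc2)OC1c1c[nH]c2ccccc12`, gives > 30 ug/mL in this assay, once more a limit. The steps among these three compounds read a step that the two limits leave unreadable from compound 1 to compound 2, a step that the two limits leave unreadable from compound 1 to compound 3 and a step that the two limits leave unreadable from compound 2 to compound 3, and what unites the three values is the limit of > 30 ug/mL in this assay, at which 3 of the 3 values shown sit.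

Compound 4, `O=C(/C=C\c1ccc(Cl)cc1)N1N=C(c2ccncc2)OC1c1c[nH]c2ccccc12`, has not yet been measured in this assay. It differs from compound 1 by 4-chlorophenyl in place of 2-hydroxyphenyl on a double-bonded chain carbon bound to a double-bonded chain carbon. The measured steps that bear on this change are a step that the two limits leave unreadable from compound 1 to compound 2 and a step that the two limits leave unreadable from compound 1 to compound 3, both of which exchange the same 2-hydroxyphenyl for 4-nitrophenyl or 4-fluorophenyl, and neither yields a readable size. Nothing in the three values suggests a move away from the limit. The step from compound 1 to compound 4 is accordingly estimated as a step that the limit leaves unreadable from compound 1 to compound 4, with no direction beyond the scatter expected. Compound 4 is expected to give about 45 ug/mL, within 20 ug/mL to 120 ug/mL, and most likely to be reported only as a limit in this assay.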

Compound 4, concentration for 50% growth inhibition: > 30 ug/mL
Compound 4: a limit, no number (the forecaster's own chance of this, stated with the estimate: 80%); the middle value lies beyond the limit too.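

Among the compounds shown here, no step to compound 4 from compound 1, compound 2 or compound 3 can be read in this assay. All four compounds stop at the same limit of the assay, not at a number: the limit of > 30 ug/mL in this assay, at which 4 of the 4 values shown sit. The compounds shown leave open how strongly any of them inhibits growth, and whether exchanging these aromatic groups changes it at all.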